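Furan-3-yl for thiophen-2-yl on a nucleoside core

The source may report more compounds than this note shows. Statements on the series, on what has been measured and on what is new or still open speak of the compounds shown alone.

Measured so far:
compound 1, `Cc1nc(N)c2c(-c3ccoc3)cn([C@@H]3O[C@H](CO)[C@@H](O)[C@H]3O)c2n1`, > 20000 nM
compound 2, `Nc1nc(N)c2c(-c3cccs3)cn([C@@H]3O[C@H](CO)[C@@H](O)[C@H]3O)c2n1`, > 20000 nM

In a functional assay on K562 cells (Homo sapiens), read by MTT assay, with a stated time of 72 h (on this read-out lower numbers stand for stronger inhibition and higher numbers for weaker inhibition), compound 2 gives > 20000 nM, which is a limit of the assay and not a number. For compound 1 the reading is > 20000 nM, again a limit. Compound 2 therefore stands at the limit, and so does every other value in hand, as summed up in the limit of > 20000 nM in this assay, at which 2 of the 2 values shown sit.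

The next compound is compound 3, `Nc1nc(N)c2c(-c3ccoc3)cn([C@@H]3O[C@H](CO)[C@@H](O)[C@H]3O)c2n1`. Its change from compound 2 is furan-3-yl in place of thiophen-2-yl on an aromatic carbon. Among the compounds with values here, no step between two measured compounds is known, so no size for this change can be taken from the data; compound 1, which also carries furan-3-yl, sits at the limit as well.

The expectation is that compound 3 also shows no inhibition within the scatter, the step that the limit leaves unreadable from compound 2 to compound 3 being expected to be none beyond it. Compound 3 is estimated at 30000 nM, range 10000 nM to 100000 nM.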

Compound 3, half-maximal inhibitory concentration: > 20000 nM
Compound 3 was reported as a limit; the forecaster's own chance of this, stated with the estimate: 85%; the middle value lies beyond the limit too.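

No step can be read between compound 3 and either compound 2 or compound 1, all three sitting at the same limit: the limit of > 20000 nM in this assay, at which 3 of the 3 values shown sit.

The compounds shown leave open what furan-3-yl in place of thiophen-2-yl, or amino in place of methyl, does to inhibition on the shared core.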